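Three Nucleosides at the Limit, and a Smaller Aryl Group

The compounds below may be only part of what the source reports. "The series", "measured", "known", "first", "only" and "open" are said of these compounds alone.

Compound 1 `COc1nc(N)nc2c1c(-c1cc3ccccc3o1)cn2[C@@H]1O[C@H](CO)[C@@H](O)[C@H]1O` was tested in a functional assay on HepG2 cells (Homo sapiens) for antiproliferative activity, read by XTT assay, with a stated time of 72 h; on this read-out lower numbers stand for stronger inhibition and higher numbers for weaker inhibition. In this assay compound 1 gives > 20000 nM, which is a limit of the assay rather than a measured number. Two further compounds share its core. Compound 2 `Nc1nc(N)c2c(-c3cc4ccccc4o3)cn([C@@H]3O[C@H](CO)[C@@H](O)[C@H]3O)c2n1` carries an amino in place of methoxy on an aromatic carbon, and in this assay compound 2 gives > 20000 nM, again a limit. Compound 3 `COc1ncnc2c1c(-c1cc3ccccc3o1)cn2[C@@H]1O[C@H](CO)[C@@H](O)[C@H]1O` carries hydrogen in place of amino on an aromatic carbon, and in this assay compound 3 gives > 20000 nM, also a limit. The step that the two limits leave unreadable from compound 1 to compound 2 and the step that the two limits leave unreadable from compound 1 to compound 3 are therefore both unreadable in size, because of the limit of > 20000 nM in this assay, at which 3 of the 3 values shown sit.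

Compound 4 `COc1nc(N)nc2c1c(-c1ccco1)cn2[C@@H]1O[C@H](CO)[C@@H](O)[C@H]1O` is not yet measured. It differs from compound 1 in one place: furan-2-yl in place of 1-benzofuran-2-yl on an aromatic carbon. Neither measured step touches this part of the molecule, so the measured steps give no guide to its size or direction. With every measured value sitting at the same limit, compound 4 is expected to remain weak as well, with an estimated value of 30000 nM and an expected range from 10000 nM to 100000 nM. This estimate for compound 4 means an expected step that the limit leaves unreadable from compound 1 to compound 4, most likely reported once more only as a limit.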

Compound 4, half-maximal inhibitory concentration: > 20000 nM
Compound 4: no number, only a limit; the forecaster's own chance of this, stated with the estimate: 85%; the middle value does not contradict the limit.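

In this assay compound 4 gives > 20000 nM as a limit, not a number. No step from compound 1 to compound 4 can be read, because both compounds stop at the same limit: the limit of > 20000 nM in this assay, at which 4 of the 4 values shown sit.

The compounds shown leave open how strongly any of them truly acts on these cells, and whether any of these changes alters that activity.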